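Removing the Pyridinyl Arm: Expected Clearance of Compound 3

A few compounds are considered here, and "the series" means these few. Any claim that something is new, unique, unknown or untested is made for them only; others in the source may bear on it.

Compound 1 `O=C(N[C@H]1CCOC[C@@H]1O)c1cn(Cc2ccc(-n3cccn3)cc2)c2cccnc12`: < 8 mL/min/kg in an ADME assay on liver for metabolic stability, with Liver microsome (Homo sapiens) as the target, using microsomes (a lower number here means slower removal, a higher number faster removal of the compound), a limit of the assay.
Compound 2 `O=C(N[C@H]1CCCC[C@@H]1O)c1cn(Cc2ccc(-n3cc(-c4ccncc4)cn3)cc2)c2cccnc12`: 140 mL/min/kg in this assay.

Compound 2 stands alone as the only numerical result in this assay; the other result sits at the limit of < 8 mL/min/kg in this assay, at which 1 of the 2 values shown sits. Compound 3 `O=C(N[C@H]1CCCC[C@@H]1O)c1cn(Cc2ccc(-n3cccn3)cc2)c2cccnc12` differs from compound 2 by hydrogen in place of pyridin-4-yl on an aromatic carbon, so that 4-(pyridin-4-yl)-1H-pyrazol-1-yl becomes 1H-pyrazol-1-yl. No measured step links two of these compounds, so the size of this change is not known from the data. The step is expected to be a 4.7-fold lower number from compound 2 to compound 3 (0.67 log units; beyond the scatter), a fall well beyond the scatter. Compound 3 is estimated at 30 mL/min/kg, within 10 mL/min/kg to 90 mL/min/kg.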

Compound 3, clearance: 59 mL/min/kg
Beside the measured number, compound 3's estimate is 2.0-fold (0.29 log units) below it; low and high end bracket the measured number.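

Replacing pyridin-4-yl with hydrogen, so that 4-(pyridin-4-yl)-1H-pyrazol-1-yl becomes 1H-pyrazol-1-yl, gives in this assay a 2.4-fold lower number from compound 2 to compound 3 (0.38 log units; beyond the scatter), which shows that this aromatic carbon affects the read-out. Placing 2-hydroxycyclohexyl instead of 3-hydroxyoxan-4-yl on the amide-type nitrogen gives an at least 7.3-fold higher number from compound 1 to compound 3 (0.86 log units; beyond the scatter), so that site matters too. Compound 1 supplies a limit, not a number: the limit of < 8 mL/min/kg in this assay, at which 1 of the 3 values shown sits.

From the compounds shown here alone, how a methyl group, an amine or a phenyl ring on that aromatic carbon would read remains open. So does the full size of the step from the limit.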